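Turning the Amide Around on a Shared Core

This account rests on a few compounds, and the source may have more. Where it says the series, first, only, none or still open, it means among the compounds named here.

Measured compounds:
compound 1 `COc1cc2oc(-c3ccc(NC(=O)c4ccc(C)cc4)cc3)cc(=O)c2c(OC)c1OC` — <= 42.6%
compound 2 `COc1cc2oc(-c3cccc(NC(=O)c4cccc(Br)c4)c3)cc(=O)c2c(O)c1OC` — 82.6%

In a functional assay on RPMI-8226 cells (Homo sapiens) for inhibition, read by sulforhodamine B assay, tested at 10 uM (on this read-out lower numbers stand for less inhibition and higher numbers for more inhibition at the one concentration tested (going by the name of the read-out)), compound 2 gives 82.6%. For compound 1 the value <= 42.6% in this assay is a limit of the assay and not a number. (the limit of <= 42.6% in this assay, at which 1 of the 2 values shown sits). Within the data shown here, compound 2 therefore holds the only full number in the set, and the two compounds differ in several places at once, so no single step between them can be measured.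

Compound 3 `COc1cc2oc(-c3cccc(C(=O)Nc4ccc(Cl)cc4)c3)cc(=O)c2c(O)c1OC` has not yet been measured. It differs from compound 2 by (4-chlorophenyl)carbamoyl in place of ((3-bromophenyl)carbonyl)amino on an aromatic carbon. The amide is thus turned around, and the halogen on the outer ring changes from bromine to chlorine, at the same place on the core.

Among the measured compounds shown here, with no measured step of this kind to lean on, the size of the change is uncertain. The expected step from compound 2 to compound 3 is a number 22.6 percentage points lower from compound 2 to compound 3 (beyond the scatter), a moderate loss in this assay, with wide uncertainty in both directions. Compound 3 is expected to give 60% in this assay, in a range from 25% to 88%.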

Compound 3, a percentage reported as inhibition, at one concentration (the size of the read-out at that concentration, not a potency): 82.6%
Compound 3: middle estimate off by 22.6 percentage points, on the low side; measured number inside the range.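

In this assay, among these compounds, the exchange of ((3-bromophenyl)carbonyl)amino for (4-chlorophenyl)carbamoyl on this aromatic carbon gives no change at the digits printed from compound 2 to compound 3 (within the scatter) and is the first step in the set that can be read. At this place on the shared core, and at the one concentration tested, the amide can therefore be turned around, with a 4-chlorophenyl ring in place of a 3-bromophenyl ring, without any loss beyond the usual scatter of the read-out. Nothing in the information shown accounts for this outcome.

From the compounds shown here alone, the amide direction, the choice of halogen and the halogen's place on the outer ring all changed in this one step, so the share of each remains unknown, and steps to compound 1 cannot be read. Also open, going by these compounds, is whether the read-out would hold with a carboxylic acid or an amine on the outer ring in place of the chlorine, and whether compound 2 and compound 3 would still match at other concentrations.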